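The source may hold more compounds than are shown below. What is called first, only, known or untested is meant among the compounds shown, and "the series" means these compounds.

Three compounds share a core bearing a furan-2-ylmethyl-substituted diaminopropyl chain and differ only in the group on one aromatic carbon. Compound 1 `COc1ccccc1Oc1ccc2c(NCCCNCc3ccco3)ccnc2c1` gives 9.28 in a physicochemical assay for acid dissociation. Compound 2 `c1ccc(-c2ccc3c(NCCCNCc4ccco4)ccnc3c2)cc1` gives 9.47, and compound 3 `Fc1ccc(Oc2ccc3c(NCCCNCc4ccco4)ccnc3c2)cc1` gives 9.28. The steps among them are all small: a number 0.19 log units higher from compound 1 to compound 2 (within the scatter), no change at the digits printed from compound 1 to compound 3 (within the scatter) and a number 0.19 log units lower from compound 2 to compound 3 (within the scatter). Compound 3 thus sits at the same value as compound 1, and its gap to compound 2 is within the scatter, so the three numbers cannot be told apart.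

Compound 4 `Fc1ccc(Cc2ccc3c(NCCCNCc4ccco4)ccnc3c2)c(Cl)c1` is the next step. 2-chloro-4-fluorobenzyl in place of 4-fluorophenoxy on an aromatic carbon The bearing steps are those from compound 1 to compound 2 and from compound 2 to compound 3, which also exchange the group on that aromatic carbon; neither moved the number beyond the scatter. The estimated step is a number 0.02 log units higher from compound 3 to compound 4 (within the scatter), that is, none beyond the scatter. Compound 4 is therefore expected to give 9.3, between 9 and 9.6.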

Compound 4, acid dissociation constant: 9.47
Beside the measured number, compound 4's estimate is 0.17 log units below it; the measured number falls inside the stated range.
By their numbers in this assay, from the lowest: compounds 1, 3, 2 and 4 (each within the scatter of the next).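

Among the compounds shown here, the group entering here, 2-chloro-4-fluorobenzyl, is the first at this aromatic carbon to carry a chlorine, and it has no hydrogen-bond acceptor, whereas 4-fluorophenoxy has one. In this assay the exchange gives a number 0.19 log units higher from compound 3 to compound 4 (within the scatter), and the comparisons with the other two groups give no change at the digits printed from compound 2 to compound 4 (within the scatter) and a number 0.19 log units higher from compound 1 to compound 4 (within the scatter), so all four compounds still cannot be told apart, even with this wider range of groups at the position. No supporting data are available to explain this reading.

All four groups at this position contain an aromatic ring of carbon only, so a basic amine such as piperidine or a carboxylic acid there remains untested in what is shown. As far as these compounds go, the furan-2-ylmethyl end of the chain is also the same throughout, so the effect of replacing it with a simple alkyl group remains open.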